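Adding a 4-chlorobenzyl group to compound 2

The source may hold more compounds than are shown below. What is called first, only, known or untested is meant among the compounds shown, and "the series" means these compounds.

Measured in a functional assay on A549 cells (Homo sapiens) for cytotoxicity, read by WST assay, with a stated time of 24 h; a lower number here means a stronger inhibitor, a higher number a weaker inhibitor:
- Compound 1 `N#C/C(=C\c1cn(Cc2ccc(Cl)cc2)c2ccc(Br)cc12)C(=O)c1c[nH]c2ccccc12`: 14000 nM
- Compound 2 `N#C/C(=C\c1c[nH]c2ccccc12)C(=O)c1c[nH]c2ccccc12`: 16100 nM

Only these two compounds have been measured so far. Compound 2, at 16100 nM, lies within the scatter of compound 1, so no order can be read between them.

Compound 3 `N#C/C(=C\c1cn(Cc2ccc(Cl)cc2)c2ccccc12)C(=O)c1c[nH]c2ccccc12` is made from compound 2 by one change: 4-chlorobenzyl in place of hydrogen on an aromatic nitrogen. Within the data shown here, no measured pair shows this change alone. Among the measured compounds shown here, the only guide is compound 1, which also carries a 4-chlorobenzyl group and gives 14000 nM in this assay. On that evidence, no change beyond the scatter is expected, though the range is left wide.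

The expected move is a 1.3-fold lower number from compound 2 to compound 3 (0.13 log units; within the scatter). Compound 3 is estimated at 12000 nM, with an expected range from 4000 nM to 30000 nM.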

Compound 3, half-maximal inhibitory concentration: > 50000 nM
Compound 3: no number, only a limit; the forecaster's own chance of this, stated with the estimate: 10%; middle value at least 4.1-fold (0.61 log units) from the limit.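

In this assay, the value of compound 3 is a limit of the assay and not a number: the limit of > 50000 nM in this assay, at which 1 of the 3 values shown sits. Placing 4-chlorobenzyl on this aromatic nitrogen is therefore not a neutral change, as it gives an at least 3.1-fold higher number from compound 2 to compound 3 (0.49 log units; beyond the scatter), something the two earlier compounds could not show. The step of an at least 3.5-fold higher number from compound 1 to compound 3 (0.55 log units; beyond the scatter), with hydrogen in place of bromo on an aromatic carbon, shows that the outcome for compounds carrying 4-chlorobenzyl also depends on that bromo.

Still open, going by these compounds, is how a methyl group, an unsubstituted benzyl group or a chain ending in an amine on the same nitrogen would compare with 4-chlorobenzyl. On these data alone, it also remains open whether bromo on the core of compound 2, with the nitrogen hydrogen kept, would shift the number at all.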